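This account rests on a few compounds, and the source may have more. Where it says the series, first, only, none or still open, it means among the compounds named here.

Measured so far: compound 1 `ClCc1ccccc1Cn1cnc2c(Cl)nc(Cl)nc21` with 210 nM, compound 2 `ClCc1cccc(Cn2cnc3c(Cl)nc(Cl)nc32)c1` with 1580 nM, and compound 3 `Nc1nc(Cl)c2ncn(Cc3ccccc3CCl)c2n1` with 3390 nM in a functional assay on OVCAR-3 cells (Homo sapiens) for cytotoxicity, read by sulforhodamine B assay, with a stated time of 48 h; on this read-out higher numbers stand for weaker inhibition of growth and lower numbers for stronger inhibition of growth.

Compound 1 and compound 2 share the same atoms, joined differently; the difference between the two cores is not broken down here. Compound 2 stands second highest of the three numbers, and its values against compound 1 and compound 3 both lie beyond the scatter.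

One change is seen twice. From compound 1 to compound 3 it is amino in place of chloro on an aromatic carbon, and it gave a 16-fold higher number from compound 1 to compound 3 (1.21 log units; beyond the scatter). Compound 4 `Nc1nc(Cl)c2ncn(Cc3cccc(CCl)c3)c2n1`, not yet measured, carries the same change from compound 2: amino in place of chloro on an aromatic carbon.

The expectation for compound 4 rests on this one measured step, so a step of about an 11-fold higher number from compound 2 to compound 4 (1.06 log units; beyond the scatter) is estimated, perhaps somewhat smaller. The value of compound 4 in this assay is estimated at 18000 nM, between 5000 nM and 60000 nM.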

Compound 4, concentration for 50% growth inhibition: 720 nM
Compound 4: middle estimate off by 25-fold (1.40 log units), on the high side; the whole stated range lies above it.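

In this assay, amino in place of chloro on an aromatic carbon gave a 2.2-fold lower number from compound 2 to compound 4 (0.34 log units; beyond the scatter), so the change carried over from one core to the other in neither direction nor size: the same change on two cores in this assay, a 16-fold higher number (1.21 log units; beyond the scatter) from compound 1 to compound 3 and a 2.2-fold lower number (0.34 log units; beyond the scatter) from compound 2 to compound 4, 35-fold (1.55 log units) apart, beyond the scatter of two such steps. Compound 1 and compound 2 share the same atoms, joined differently, and that difference in the core is all that separates the two steps. This shows that, for these two cores, the result of the change on one did not predict its result on the other, but it does not show why, or what the change would do on a further core.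

The compounds shown leave open whether a methylamino or methoxy group at the same place would also give opposite steps on the two cores. They also leave open how a hydroxyl group in place of the remaining chloro group would fare.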